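Chloro in place of hydrogen on the outer phenyl ring

The source may report more compounds than this note shows. Statements on the series, on what has been measured and on what is new or still open speak of the compounds shown alone.

Compound 2 `O=C(O)c1ccc(C(=O)c2ccc(C(=O)c3ccccc3)cc2)cc1` was tested in an assay on CHO cells for inhibition of 3-oxo-5-alpha-steroid 4-dehydrogenase 2 (Homo sapiens) (a higher number here means a weaker inhibitor, a lower number a stronger inhibitor), where compound 2 gives 40 nM. Going by the values given here, of the two numbers measured so far this is the higher one; the only neighbour is compound 1 `Cc1ccc(C(=O)c2ccc(C(=O)c3ccc(C(=O)O)cc3)cc2)cc1`, which in this assay gives 10 nM. Among the compounds with values here, the single step that separates them, a 4.0-fold higher number from compound 1 to compound 2 (0.60 log units; beyond the scatter), swaps a methyl on the outer phenyl ring for hydrogen and makes the inhibitor weaker. Compound 3 `O=C(O)c1ccc(C(=O)c2ccc(C(=O)c3ccc(Cl)cc3)cc2)cc1` reverses the direction of that exchange with a different group: the change is chloro in place of hydrogen on an aromatic carbon, a phenyl becoming a 4-chlorophenyl. Within the data shown here, the one comparable step in this assay is the methyl-for-hydrogen step from compound 1 to compound 2, which points to a lower number once the same position is occupied again. Compound 3 is therefore expected to reach about 15 nM, between 5 nM and 50 nM, an estimated step of a 2.7-fold lower number from compound 2 to compound 3 (0.43 log units; beyond the scatter).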

Compound 3, inhibition constant: 35 nM
Compound 3: middle estimate off by 2.3-fold (0.37 log units), on the low side; the range from low to high includes it.
By their numbers in this assay, from the lowest: compound 1; then compounds 3 and 2 (each within the scatter of the next).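

In this assay occupying this position is not enough by itself: the step of a 1.1-fold lower number from compound 2 to compound 3 (0.06 log units; within the scatter) leaves chloro and hydrogen on the outer phenyl ring with no difference that can be told apart. Methyl is the group that stands apart among the three, and the step of a 3.5-fold higher number from compound 1 to compound 3 (0.54 log units; beyond the scatter) shows that chloro does not match it at the same place, so the gain seen with methyl does not carry over to every group put there. Nothing at hand explains why methyl and chloro differ here.

As far as these compounds go, whether an ethyl, a methoxy or an amine at this position would track methyl or chloro remains open. So does whether the advantage of methyl would hold at other places on the outer phenyl ring.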